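The source may hold more compounds than are shown below. What is called first, only, known or untested is meant among the compounds shown, and "the series" means these compounds.

Measured compounds:
compound 1, `CC1=C(C(=O)OCc2cccnc2)C(c2cccs2)C2=C(CCCC2=O)N1`: 1.4
compound 2, `CC1=C(C(=O)OCc2cccnc2)C(c2ccc(Cl)cc2)C2=C(CCCC2=O)N1`: 1.87
compound 3, `CC1=C(C(=O)OCc2ccccn2)C(c2ccc(Cl)cc2)C2=C(CCCC2=O)N1`: 2.24

All three values come from a physicochemical assay for lipophilicity, measured as octanol-water partition; on this read-out higher numbers stand for higher lipophilicity and lower numbers for lower lipophilicity. Compound 3 sits highest of the three in this assay, with compound 2 nearest and compound 1 furthest. From compound 2 to compound 3 the difference is pyridin-2-yl in place of pyridin-3-yl on a saturated chain carbon bound to an oxygen next to a carbonyl group, and the corresponding step reads a number 0.37 log units higher from compound 2 to compound 3 (beyond the scatter). From compound 2 to compound 1 the change is thiophen-2-yl in place of 4-chlorophenyl on a saturated ring carbon, which gives a number 0.47 log units lower from compound 2 to compound 1 (beyond the scatter).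

The unmeasured compound 4, `CC1=C(C(=O)OCc2ccccn2)C(c2cccs2)C2=C(CCCC2=O)N1`, stands to compound 3 as compound 1 stands to compound 2: the change is thiophen-2-yl in place of 4-chlorophenyl on a saturated ring carbon. The place of this change is described in identical terms for both pairs, so it is the same change, made twice in this set; the two cores differ only by pyridin-2-yl in place of pyridin-3-yl on a saturated chain carbon bound to an oxygen next to a carbonyl group. It has been measured once, between compound 2 and compound 1, where it lowered the read-out by a modest amount that is beyond the scatter.

On that basis the expected step is a number 0.47 log units lower from compound 3 to compound 4 (beyond the scatter), taken as a near repeat of the step seen from compound 2 to compound 1, which rests on a number 0.47 log units lower from compound 2 to compound 1 (beyond the scatter) and on compound 3 giving 2.24 in this assay. Compound 4 is therefore estimated at 1.77 in this assay. Allowing for the scatter of this kind of measurement and for the single precedent, compound 4 is expected to fall between 1.4 and 2.1.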

Compound 4, partition coefficient: 1.77
Beside the measured number, compound 4's estimate shows no gap at the digits printed, within the range that was stated.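

In this assay, thiophen-2-yl in place of 4-chlorophenyl gives a number 0.47 log units lower from compound 3 to compound 4 (beyond the scatter), the same size as a number 0.47 log units lower from compound 2 to compound 1 (beyond the scatter), while pyridin-2-yl in place of pyridin-3-yl gives a number 0.37 log units higher from compound 1 to compound 4 (beyond the scatter), the same size as a number 0.37 log units higher from compound 2 to compound 3 (beyond the scatter). The four compounds therefore form a closed square in which each change carries from one core to the other unchanged at the digits printed, but this is a single repeat on one pair of cores and sets no rule for the series as a whole. No measurement shown accounts for the repeat, so it stands as an observation only.

On these data alone, it remains open whether the thiophen-2-yl step holds on a core where the pyridine is replaced by a carboxylic acid or an amine, or is carried on a longer chain. As far as these compounds go, it is equally open whether the pyridine step keeps its size when the saturated ring carbon bears a group other than thiophen-2-yl or 4-chlorophenyl, such as a phenyl ring carrying an amine.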